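The source may hold more compounds than are shown below. What is called first, only, known or untested is meant among the compounds shown, and "the series" means these compounds.

Within the data shown here, the three compounds measured so far share a single core and differ only in the aryl group on a carbon with a double bond to nitrogen. Compound 1 `CN(C)CCn1cnnc1-c1cc(Oc2ccc(NC(=O)N/N=C/c3ccc(O)c(Br)c3)cc2F)ccn1` carries a 3-bromo-4-hydroxyphenyl there and gives 450 nM in a functional assay on HT-29 cells (Homo sapiens) for cytotoxicity, read by MTT assay, with a stated time of 72 h; on this read-out higher numbers stand for weaker inhibition and lower numbers for stronger inhibition. Compound 2 `CN(C)CCn1cnnc1-c1cc(Oc2ccc(NC(=O)N/N=C/c3ccccc3)cc2F)ccn1` carries a plain phenyl, and in this assay compound 2 gives 1120 nM. Compound 3 `CN(C)CCn1cnnc1-c1cc(Oc2ccc(NC(=O)N/N=C/c3c(O)ccc4ccccc34)cc2F)ccn1` carries a 2-hydroxynaphthalen-1-yl, and in this assay compound 3 gives 670 nM. On these numbers compound 3 stands second highest of the three, nearer to compound 1 than to compound 2, and both of its neighbours lie within the scatter: a 1.5-fold higher number from compound 1 to compound 3 (0.17 log units; within the scatter) and a 1.7-fold lower number from compound 2 to compound 3 (0.22 log units; within the scatter). Among the measured compounds shown here, the only step beyond the scatter is a 2.5-fold higher number from compound 1 to compound 2 (0.40 log units; beyond the scatter).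

Compound 4 `COc1cc(/C=N/NC(=O)Nc2ccc(Oc3ccnc(-c4nncn4CCN(C)C)c3)c(F)c2)ccc1O` is not yet measured. Its change from compound 3 is 4-hydroxy-3-methoxyphenyl in place of 2-hydroxynaphthalen-1-yl on a carbon with a double bond to nitrogen. The entering group resembles that of compound 1, a 4-hydroxyphenyl bearing one further substituent, more than it resembles the phenyl of compound 2. For the measured compounds named here, the steps that bear on it, from compound 1 and compound 2 to compound 3, were both within the scatter, so no step beyond the scatter is expected in this assay. Compound 4 is therefore estimated at 500 nM, within 200 nM to 1200 nM, a step of a 1.3-fold lower number from compound 3 to compound 4 (0.13 log units; within the scatter).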

Compound 4, half-maximal inhibitory concentration: 120 nM
The estimate for compound 4 lay 4.2-fold (0.62 log units) above the measured number, and the stated range ends above it.
By their numbers in this assay, from the lowest: compound 4; then compounds 1, 3 and 2 (each within the scatter of the next, the first and the last beyond it).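

In this assay, the 4-hydroxy-3-methoxyphenyl on a carbon with a double bond to nitrogen separates compound 4 from all the other compounds shown, with a 5.6-fold lower number from compound 3 to compound 4 (0.75 log units; beyond the scatter), a 9.3-fold lower number from compound 2 to compound 4 (0.97 log units; beyond the scatter) and a 3.8-fold lower number from compound 1 to compound 4 (0.57 log units; beyond the scatter), which makes compound 4 the strongest of the four on this read-out. Among these compounds, the last of these steps shows what the earlier compounds could not: with the hydroxy kept, methoxy in place of bromo on an aromatic carbon is enough to move the number beyond the scatter, so this position responds to the identity of a single substituent and not only to the difference between a plain phenyl and a substituted aryl group, which was the one change beyond the scatter among compounds 1, 2 and 3. Nothing available on these compounds gives a reason for this difference.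

The compounds shown leave open whether the methoxy gives this result by itself or only together with the hydroxy. They also leave open whether an ethoxy or a dimethylamino group in place of the methoxy would keep the number as low as that of compound 4.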